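The source may report more compounds than this note shows. Statements on the series, on what has been measured and on what is new or still open speak of the compounds shown alone.

Measured so far:
- compound 1 `CC(C)=CCC[C@]1(C)/C=C/[C@@H](OC(=O)C=C(C)C)[C@](C)(O)/C=C/C(=O)/C(CN(C)C)=C\C1`: 140 nM
- compound 2 `CC(C)=CCC[C@](C)(/C=C/[C@@H](OC(=O)C=C(C)C)[C@](C)(O)/C=C/C(=O)/C=C/N1CCN(C)CC1)CC=O`: 1060 nM

In a functional assay on HL-60 cells (Homo sapiens) for antiproliferative activity, read by MTT assay, with a stated time of 48 h (on this read-out higher numbers stand for weaker inhibition and lower numbers for stronger inhibition), compound 1 gives 140 nM, the lowest of the two numbers in hand. Compound 2 gives 1060 nM in this assay, a higher number, and the gap between the two lies beyond the usual scatter of repeated measurements. The two structures differ in more than one place, so nothing about a single change can be drawn from the pair; the values only show that compound 1 is the stronger inhibitor of the two.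

Compound 3 `CC(C)=CCC[C@]1(C)/C=C/[C@@H](OC(=O)C=C(C)C)[C@](C)(O)/C=C/C(=O)/C(C(=O)N2CCCC2)=C\C1` has not been measured. It differs from compound 1 in one place:
(pyrrolidin-1-yl)carbonyl in place of (dimethylamino)methyl on a double-bonded ring carbon

Going by the values given here, no measured step of this kind is available, so the size of the change in this assay is open. A change of this size at that position would not be expected to leave the number unchanged, but neither is a large shift expected; a modest increase in the number, a somewhat weaker inhibition than compound 1 at 140 nM, is the working expectation.

For compound 3 the estimated value in this assay is 300 nM, with a range of 80 nM to 1200 nM. The expected step of a 2.1-fold higher number from compound 1 to compound 3 (0.33 log units; beyond the scatter) is thus a small loss in potency, close to the edge of the scatter.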

Compound 3, half-maximal inhibitory concentration: 12300 nM
For compound 3 the middle estimate is 41-fold (1.61 log units) below the measured one; the measured number lies above the stated range.
By their numbers in this assay, from the lowest: compound 1; then compound 2; then compound 3.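

In this assay the exchange of (dimethylamino)methyl for (pyrrolidin-1-yl)carbonyl on the double-bonded ring carbon gives an 88-fold higher number from compound 1 to compound 3 (1.94 log units; beyond the scatter) and so shows that a single change at this position of the shared core can move the number by a large step. This position therefore does not accept every substituent equally, at least for this pair. The step is large even though the two groups have the same printed counts of hydrogen-bond donors and acceptors and neither carries a net charge, and no measurement on either group bears on what lies behind the step.

The exchange alters the carbonyl, the ring and the size of the group at once, so this pair cannot say which of these carries the loss. A (pyrrolidin-1-yl)methyl group or a (dimethylamino)carbonyl group on the same ring carbon would separate the carbonyl from the ring, while a carboxylic acid there remains an open case in this assay.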